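From Compound 3 to Compound 4 in a Receptor Agonist Series

This account rests on a few compounds, and the source may have more. Where it says the series, first, only, none or still open, it means among the compounds named here.

Measured compounds:
compound 1, `COc1cc2c(cc1N1C[C@@H](C)N(C)[C@@H](C)C1)N(S(=O)(=O)c1cccc(Br)c1)CC2`, 0.7;
compound 2, `COc1cc2c(cc1N1C[C@@H](C)N[C@@H](C)C1)N(S(=O)(=O)c1ccc(-c3ccon3)s1)CC2`, 0.9;
compound 3, `COc1cc2c(cc1N1CCN[C@@H](C)C1)N(S(=O)(=O)c1ccc(-c3ccccn3)s1)CC2`, 1.

In a functional assay with growth hormone secretagogue receptor type 1 (Homo sapiens) as the target (a higher number here means a larger maximal response, a lower number a smaller maximal response), compound 3 gives the largest of the three numbers. Compound 2 lies within the usual scatter of compound 3, so no order can be read between those two, whereas compound 1 sits below compound 3 by a gap beyond the scatter. Compound 4, `COc1cc2c(cc1N1C[C@H](C)NC(C)(C)C1)N(S(=O)(=O)c1ccc(-c3ccccn3)s1)CC2`, is not yet measured. It differs from compound 3 in one place: a group of 9 heavy atoms (7 carbon, 2 nitrogen; one six-membered non-aromatic ring with 2 hetero atoms) in place of a group of 7 heavy atoms (5 carbon, 2 nitrogen; one six-membered non-aromatic ring with 2 hetero atoms), on an aromatic carbon. Among the compounds with values here, no measured pair in this set shows such a change, so nothing here tells how this assay answers it. The step a number 0.10 lower from compound 3 to compound 4 (within the scatter) is therefore expected to stay within the scatter. Compound 4 is estimated at 0.9, between 0.7 and 1.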

Compound 4, intrinsic activity: the largest response reached, as a fraction of the reference agonist's: 1
Estimate against measurement, compound 4: 0.10 below, within the range that was stated.
By their numbers in this assay, from the lowest: compound 1; then compounds 2, 3 and 4 (each within the scatter of the next).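

In this assay, within the data shown here, replacing the 3-methylpiperazin-1-yl group with the ring of 9 heavy atoms on the aromatic carbon gives no change at the digits printed from compound 3 to compound 4 (within the scatter) and offers the first reading of a change at this place alone. At this position, the larger ring keeps the maximal response within the scatter of the 3-methylpiperazin-1-yl compound, although this single pair sets no general rule. No supporting information accounts for this result. The compounds shown leave open how a morpholine ring or an open-chain amine on this aromatic carbon would fare in this assay.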